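Amide substituent change in a cell cytotoxicity series

The source may report more compounds than this note shows. Statements on the series, on what has been measured and on what is new or still open speak of the compounds shown alone.

Compound 1, `C=CC1=C(C(=O)NCc2ccc(Cl)cc2)C(c2ccc(F)cc2)OC1`: > 100000 nM
Compound 2, `C=CC1=C(C(=O)Nc2ccc(OCC)cc2)C(c2ccc(OC)cc2)OC1`: > 100000 nM

In a functional assay on HeLa cells (Homo sapiens) for cytotoxicity, read by MTT assay, with a stated time of 24 h (a lower number here means a stronger inhibitor, a higher number a weaker inhibitor), compound 1 gives only a limit of the assay, > 100000 nM. Compound 2 likewise reaches only a limit in this assay, > 100000 nM. Compound 2 thus stands at the ceiling of the recorded values, and compound 1 stands there with it, as the limit of > 100000 nM in this assay, at which 2 of the 2 values shown sit, shows. Among the compounds with values here, no two measured compounds differ in a single place, so no measured step is available to build on. Compound 3, `C=CC1=C(C(=O)NCCCCC)C(c2ccc(OC)cc2)OC1`, is not yet measured in this assay; it differs from compound 2 by pentyl in place of 4-ethoxyphenyl on an amide-type nitrogen. Within the data shown here, with no measured step to guide it, the account expects no step in this assay beyond the usual scatter, and compound 3 is expected to remain at the limit much as compound 2 does. Compound 3 is expected to give 150000 nM in this assay, within 50000 nM to 500000 nM. The step this expectation implies, estimated rather than measured, is a step that the limit leaves unreadable from compound 2 to compound 3.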

Compound 3, half-maximal inhibitory concentration: > 100000 nM
Compound 3 was reported as a limit (the forecaster's own chance of this, stated with the estimate: 85%); the middle value lies beyond the limit too.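

Compound 2 and compound 3 are both reported only as limits in this assay, and no step can be read between them. The compounds shown leave open whether any amide substituent on the shared core gives a measurable value in this assay.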